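The source may report more compounds than this note shows. Statements on the series, on what has been measured and on what is new or still open speak of the compounds shown alone.

Compound 1, `COc1ccc(C(=O)NNc2c(Br)cccc2Br)cc1`, in a toxicity assay on MDCK cells (Canis lupus familiaris) for cytotoxicity, read by CCK-8 assay, with a stated time of 48 h; a lower number here means that less compound is tolerated, a higher number that more compound is tolerated: > 100000 nM
Compound 2, `CCOc1ccc(C(=O)NNc2cccc(Br)c2)cc1`, in this assay: > 100000 nM

Both results are limits of the assay rather than numbers. Compound 1 stands at the limit of > 100000 nM in this assay, at which 2 of the 2 values shown sit, so nothing in the numbers sets it apart from compound 2. The unmeasured compound 3 is `O=C(NNc1c(Br)cccc1Br)c1ccc(B(O)O)cc1`. It differs from compound 1 in one place: a group of 3 heavy atoms (1 boron, 2 oxygen; no ring) in place of a group of 2 heavy atoms (1 carbon, 1 oxygen; no ring), on an aromatic carbon. Within the data shown here, no pair of measured compounds here differs in a single place, so the size of this change cannot be read from a measured step. Compound 1 gives > 100000 nM, a limit of the assay and not a number. Resting on that value of compound 1, the step of a number no higher from compound 1 to compound 3 (the limit leaves the size open) is expected to be none beyond the usual scatter. Compound 3 is expected to give 100000 nM in this assay, within a range from 30000 nM to 300000 nM, most likely reported again only as a limit.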

Compound 3, half-maximal cytotoxic concentration: > 100000 nM
Compound 3 ended at the assay's limit; the forecaster's own chance of this, stated with the estimate: 80%; the middle value lies on the limit itself.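

Among these compounds, compound 1 and compound 3 each end at a limit of this assay and not at a number, and no step between them can be read. The compounds shown leave open at what concentration any of them would become toxic to these cells: the limit of > 100000 nM in this assay, at which 3 of the 3 values shown sit.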